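A few compounds are considered here, and "the series" means these few. Any claim that something is new, unique, unknown or untested is made for them only; others in the source may bear on it.

Measured so far in an assay on isolated protein for agonist activity at Bile acid receptor (Homo sapiens), read by AlphaScreen, with a stated time of 30 min; a higher number here means a larger maximal response, a lower number a smaller maximal response:
compound 1 `COc1ccccc1-c1ccc([C@H]2S[C@@H](C)C(=O)Nc3c2c(C)nn3-c2ccccc2C)cc1` gives 50%;
compound 2 `COc1ccc(Oc2ccc([C@H]3S[C@@H](C)C(=O)Nc4c3c(C)nn4-c3ccccc3C)cc2)cc1` gives 70%;
compound 3 `Cc1ccccc1-n1nc(C)c2c1NC(=O)[C@H](C)S[C@@H]2c1ccc(Oc2ccccc2)cc1` gives 118%.

Compound 3 stands at the top of these three numbers. Its lead over the nearest compound is a number 48 percentage points higher from compound 2 to compound 3 (beyond the scatter), and over the furthest it is a number 68 percentage points higher from compound 1 to compound 3 (beyond the scatter), both beyond the usual scatter. The next compound to be measured is compound 4 `COc1cccc(Oc2ccc([C@H]3S[C@@H](C)C(=O)Nc4c3c(C)nn4-c3ccccc3C)cc2)c1`. It differs from compound 3 in a single place: methoxy in place of hydrogen on an aromatic carbon. For the measured compounds named here, only one measured step bears directly on this change, and it runs the other way: a number 48 percentage points higher from compound 2 to compound 3 (beyond the scatter), where the methoxy on the phenoxy ring of compound 2 was taken away. Compound 4 puts a methoxy back onto that ring, though as 3-methoxyphenoxy rather than the 4-methoxyphenoxy of compound 2, so the earlier step is a guide, not a copy. The methoxy is therefore expected to lower the maximal response, most likely by less than the full measured step; the expected step is a number 33 percentage points lower from compound 3 to compound 4 (beyond the scatter). Compound 4 is estimated to give 85%, with a likely range from 55% to 115%.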

Compound 4, largest response reached (reported as efficacy), in percent of the reference or control that the assay uses: 120%
For compound 4 the middle estimate is 35 percentage points below the measured one; the whole stated range lies below it.
By their numbers in this assay, from the lowest: compound 1; then compound 2; then compounds 3 and 4 (each within the scatter of the next).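

In this assay, going from phenoxy to 3-methoxyphenoxy gives a number 2 percentage points higher from compound 3 to compound 4 (within the scatter), so a methoxy on the phenoxy ring does not by itself cost maximal response, and the two compounds cannot be told apart here. For the compounds shown here, what the earlier compounds could not show is that the place of the methoxy on this ring counts: swapping 4-methoxyphenoxy for 3-methoxyphenoxy gives a number 50 percentage points higher from compound 2 to compound 4 (beyond the scatter), and 3-methoxyphenoxy in place of 2-methoxyphenyl gives a number 70 percentage points higher from compound 1 to compound 4 (beyond the scatter), a step that changes both the linker oxygen and the place of the methoxy at once. Nothing available here explains why the 3-methoxyphenoxy and 4-methoxyphenoxy groups differ so much.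

Still open, from the compounds shown here alone, is how a 2-methoxyphenoxy group would compare, which would complete the set of methoxy places on this ring. Also open, going by these compounds, is whether the ring carbon carrying the methoxy in compound 4 would accept a different group, such as an ethoxy, a hydroxyl, an amine or a carboxylic acid, with the same maximal response.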